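Sulfonyl for carbonyl on the ring nitrogen: compound 4

The source may report more compounds than this note shows. Statements on the series, on what has been measured and on what is new or still open speak of the compounds shown alone.

Three compounds of the series have numbers in a functional assay on HCC1806 cells (Homo sapiens) for inhibition, read by sulforhodamine B assay, tested at 10 uM; on this read-out higher numbers stand for more inhibition at the one concentration tested (going by the name of the read-out) and lower numbers for less inhibition. Compound 3 `CN(C)c1ccc(C2CC(c3ccc(-n4ccnc4)cc3)=NN2C(=O)c2cc(Cl)cc(Cl)c2)cc1` gives 44.5% and stands highest of the three. Compound 1 `CN(C)c1ccc(C2CC(c3ccc(-n4cncn4)cc3)=NN2S(=O)(=O)c2ccc(C#N)cc2)cc1` gives 33.1%, beyond the scatter below compound 3. Compound 2 `COC(=O)CC(=O)N1N=C(c2ccc(-n3ccnc3)cc2)CC1c1ccc(N(C)C)cc1` gives 2.1%, the lowest number. Among the measured compounds shown here, the one single-point step measured so far, a number 42.4 percentage points higher from compound 2 to compound 3 (beyond the scatter), sits on the same ring nitrogen that is changed here, so the substituent at this place clearly matters in this assay .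

Compound 4 `CN(C)c1ccc(C2CC(c3ccc(-n4ccnc4)cc3)=NN2S(=O)(=O)c2ccc(C#N)cc2)cc1` differs from compound 3 by (4-cyanophenyl)sulfonyl in place of (3,5-dichlorophenyl)carbonyl on an amine nitrogen in a ring. For the measured compounds named here, no step for this exact exchange has been measured. Going by the values given here, compound 1 also carries a (4-cyanophenyl)sulfonyl on the ring nitrogen and gives a number about a scatter width below compound 3, which is the only guide available. Compound 4 is therefore expected near that level, with an estimated step of a number 9.5 percentage points lower from compound 3 to compound 4 (within the scatter) that is small, downward at most and possibly not beyond the scatter. The estimate for compound 4 in this assay is 35%, within 15% to 55%.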

Compound 4, a percentage reported as inhibition, at one concentration (the size of the read-out at that concentration, not a potency): 4.7%
Beside the measured number, compound 4's estimate is 30.3 percentage points above it; the measured number lies below the stated range.
By their numbers in this assay, from the lowest: compounds 2 and 4 (each within the scatter of the next); then compound 1; then compound 3.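

In this assay, the step of a number 39.8 percentage points lower from compound 3 to compound 4 (beyond the scatter) shows that (4-cyanophenyl)sulfonyl does not hold the level of (3,5-dichlorophenyl)carbonyl on the ring nitrogen when the 4-(1H-imidazol-1-yl)phenyl group is present. The step of a number 2.6 percentage points higher from compound 2 to compound 4 (within the scatter) places this sulfonyl group level with ((methoxycarbonyl)methyl)carbonyl at the same position. With the sulfonyl group held constant, the step of a number 28.4 percentage points lower from compound 1 to compound 4 (beyond the scatter) shows that 1H-imidazol-1-yl in place of 1H-1,2,4-triazol-1-yl also changes the number, so the reading at the ring nitrogen cannot be taken apart from that second place. Nothing in hand accounts for these steps. Still open, going by these compounds, is whether the aryl group or its link carries the number of compound 3, which (3,5-dichlorophenyl)sulfonyl or (4-cyanophenyl)carbonyl on the ring nitrogen would separate.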